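This account rests on a few compounds, and the source may have more. Where it says the series, first, only, none or still open, it means among the compounds named here.

Three measured compounds share one core and differ only in the group on the fused ring system. In a functional assay on CCRF-CEM cells (Homo sapiens) for inhibition, read by cell counting, with a stated time of 3 days (on this read-out lower numbers stand for stronger inhibition and higher numbers for weaker inhibition), compound 1 `C=C(Br)C(=O)Nc1cccc(-c2cn3nc(-c4ccc(CC)cc4)sc3n2)c1` gives 3400 nM, compound 2 `C=C(Br)C(=O)Nc1cccc(-c2cn3nc(-c4ccccc4)sc3n2)c1` gives 960 nM, and compound 3 `C=C(Br)C(=O)Nc1cccc(-c2cn3nc(-c4ccc(OC)cc4)sc3n2)c1` gives 1200 nM. Compound 3 thus shows the second highest number of the three; its gap to compound 2 lies within the scatter, while the step of a 2.8-fold lower number from compound 1 to compound 3 (0.45 log units; beyond the scatter) lies beyond it. Compound 4 `C=C(Br)C(=O)Nc1cccc(-c2cn3nc(Cc4ccc(OC)cc4)sc3n2)c1` differs from compound 3 by 4-methoxybenzyl in place of 4-methoxyphenyl on an aromatic carbon. Among the compounds with values here, no measured step matches this change: the steps of a 3.5-fold lower number from compound 1 to compound 2 (0.55 log units; beyond the scatter) and a 1.3-fold higher number from compound 2 to compound 3 (0.10 log units; within the scatter) swap a substituent on the six-membered aromatic ring of carbon only, and none changes how that ring is attached to the core. The step of a 1.3-fold higher number from compound 3 to compound 4 (0.10 log units; within the scatter) is therefore expected to stay within the scatter, with wide uncertainty. Compound 4 is estimated at 1500 nM, with a range from 500 nM to 4500 nM.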

Compound 4, half-maximal inhibitory concentration: 2300 nM
Compound 4: middle estimate off by 1.5-fold (0.19 log units), on the low side; measured number inside the range.
By their numbers in this assay, from the lowest: compounds 2, 3, 4 and 1 (each within the scatter of the next, the first and the last beyond it).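

Attaching the ring through a carbon, as 4-methoxybenzyl in place of 4-methoxyphenyl, gives in this assay a 1.9-fold higher number from compound 3 to compound 4 (0.28 log units; within the scatter), so this change of attachment at this position leaves the number within the scatter. Set against phenyl, the same position shows a 2.4-fold higher number from compound 2 to compound 4 (0.38 log units; beyond the scatter), whereas against 4-ethylphenyl it shows a 1.5-fold lower number from compound 1 to compound 4 (0.17 log units; within the scatter). Nothing available explains these steps. Still open, as far as these compounds go, is whether a longer chain or an amine as the link would behave like 4-methoxybenzyl. Plain benzyl, without the methoxy, also remains open.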